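This account rests on a few compounds, and the source may have more. Where it says the series, first, only, none or still open, it means among the compounds named here.

Compound 2 `O=C(C1CCCN(Cc2ccc([N+](=O)[O-])cc2)C1)N1CCN(c2ccccc2Cl)CC1` carries a 4-nitrobenzyl group on the amine nitrogen of its saturated ring. Among the measured compounds shown here, in a functional assay on a cell-free system (Platelet, plasma, Homo sapiens), with stated times of 4 min and 5.5 min, tested at 0.25 uM (on this read-out higher numbers stand for a weaker effect at the one concentration tested and lower numbers for a stronger effect), compound 2 gives 28%, the lower of the two numbers measured so far, but compound 1 `O=C(C1CCCN(Cc2ccccc2F)C1)N1CCN(c2ccccc2Cl)CC1`, which gives 38%, lies within the scatter of it: the change of a number 10 percentage points lower from compound 1 to compound 2 (within the scatter) is not a real difference.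

Compound 3 `O=C(c1ccc(Br)cc1)N1CCCC(C(=O)N2CCN(c3ccccc3Cl)CC2)C1` differs from compound 2 in one place: (4-bromophenyl)carbonyl in place of 4-nitrobenzyl on an amine nitrogen in a ring. For the measured compounds named here, the only measured step, from compound 1 to compound 2, swapped one aryl for another while keeping the benzyl link, and it produced nothing beyond the scatter. Going by the values given here, no measured step speaks to replacing the benzyl link by a carbonyl link, so the expectation rests on little. Among the compounds with values here, compound 3 is therefore expected near the two known numbers, at an estimated 35% in this assay, with a wide range from 10% to 65%, which means an expected step of a number 7 percentage points higher from compound 2 to compound 3 (within the scatter).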

Compound 3, a percentage reported as activity, at one concentration (the size of the read-out at that concentration, not a potency): 47%
Estimate against measurement, compound 3: 12 percentage points below, and the stated range covers the measured number.
By their numbers in this assay, from the lowest: compounds 2, 1 and 3 (each within the scatter of the next, the first and the last beyond it).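

In this assay, among the compounds shown here, the change on the amine nitrogen in a ring gives a number 19 percentage points higher from compound 2 to compound 3 (beyond the scatter) and is the first step at this position to clear the scatter, so (4-bromophenyl)carbonyl gives a weaker effect here than 4-nitrobenzyl. The same group set against 2-fluorobenzyl gives a number 9 percentage points higher from compound 1 to compound 3 (within the scatter) and no real difference, so the carbonyl group cannot be said to weaken the effect against every benzyl group. Nothing given here explains the step from 4-nitrobenzyl.

Compound 3 changes both the link and the group on the aromatic ring at once, so the part of the change that matters stays unresolved. As far as these compounds go, a 4-bromobenzyl group on this nitrogen would separate the two, and a longer chain in place of the benzyl link also remains open.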